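The source may report more compounds than this note shows. Statements on the series, on what has been measured and on what is new or still open speak of the compounds shown alone.

Measured so far:
- compound 1 `COc1ccc(F)cc1CNCCCNc1ccnc2cc(C3CCCCC3)ccc12`: 2290 nM in an ADME assay on HepG2 cells (Homo sapiens) for cytotoxicity, read by luminescence, CellTiter-Glo and ATP content, with a stated time of 72 h; a lower number here means that less compound is needed, a higher number that more compound is needed for the effect
- compound 2 `COc1ccc(Oc2ccc3c(NCCCNCc4cc(F)ccc4OC)ccnc3c2)cc1`: 7000 nM in this assay

Among the measured compounds shown here, compound 2 gives the highest of the two numbers; its nearest neighbour is compound 1, and the single step between them, a 3.1-fold higher number from compound 1 to compound 2 (0.49 log units; beyond the scatter), is modest but beyond the scatter. Compound 3 `COc1ccc(F)cc1CNCCCNc1ccnc2cc(Cc3ccc(F)cc3Cl)ccc12` is not yet measured. It differs from compound 2 by 2-chloro-4-fluorobenzyl in place of 4-methoxyphenoxy on an aromatic carbon. For the measured compounds named here, this is the same aromatic carbon at which compound 1 and compound 2 differ, so the step of a 3.1-fold higher number from compound 1 to compound 2 (0.49 log units; beyond the scatter) is the only measured step that bears on it; it says that replacing cyclohexyl with 4-methoxyphenoxy at that carbon raised the number modestly. With 2-chloro-4-fluorobenzyl entering in place of 4-methoxyphenoxy, a modest step back toward the number of compound 1 is expected, a 2.0-fold lower number from compound 2 to compound 3 (0.30 log units; within the scatter), though the direction is uncertain. The estimate for compound 3 is 3500 nM, within 1200 nM to 10000 nM.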

Compound 3, half-maximal effective concentration: 2460 nM
The estimate for compound 3 lay 1.4-fold (0.15 log units) above the measured number, within the range that was stated.
By their numbers in this assay, from the lowest: compounds 1 and 3 (each within the scatter of the next); then compound 2.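

In this assay, 2-chloro-4-fluorobenzyl in place of 4-methoxyphenoxy gives a 2.8-fold lower number from compound 2 to compound 3 (0.45 log units; beyond the scatter) even though both groups hold 9 heavy atoms and one six-membered aromatic ring of carbon only; in the counts, they differ in hydrogen-bond acceptors, 2 in the leaving group and 0 in the entering one. The second step, a 1.1-fold higher number from compound 1 to compound 3 (0.03 log units; within the scatter), leaves 2-chloro-4-fluorobenzyl and cyclohexyl indistinguishable at this aromatic carbon, so among the three groups only 4-methoxyphenoxy stands apart, with its steps to both others beyond the scatter. Nothing at hand accounts for this difference.

Going by these compounds, whether the shift follows the acceptor count or some other difference between the groups remains open. Also open, on these data alone, is how an amine or a carboxylic acid at this aromatic carbon would compare, and whether the chlorine and fluorine of the benzyl group matter at all.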